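The compounds below may be only part of what the source reports. "The series", "measured", "known", "first", "only" and "open" are said of these compounds alone.

Compound 1 `CCC(C1CC1)n1c(=O)c(C)nc2c(-c3cc(C)c(C)cc3C)ccnc21` gives 5.2 nM in a functional assay for antagonist activity at corticotropin-releasing factor receptor 1 (Rattus norvegicus) (on this read-out lower numbers stand for stronger inhibition and higher numbers for weaker inhibition), compound 2 `COc1ccc(-c2ncnc3c2nc(C)c(=O)n3C(C2CC2)C2CC2)c(C)c1` gives 37 nM in this assay, and compound 3 `CCCC(C)n1c(=O)c(C)nc2c(-c3ccc(Cl)cc3Cl)ccnc21` gives 62 nM in this assay. Among these three numbers compound 3 holds the highest one; its gap to compound 2 lies within the usual scatter, while its gap to compound 1 lies beyond it. Compound 4 `Cc1nc2c(-c3ccc(Cl)cc3Cl)ccnc2n(C(C)C(C)C)c1=O` has the same atoms as compound 3, joined differently: isopropyl in place of propyl on a saturated chain carbon bound to an aromatic nitrogen and a saturated chain carbon. Among the compounds with values here, no two measured compounds differ in exactly this way, so the size of the step cannot be read off from the numbers given. Compound 4 is therefore expected to stay close to compound 3, with the step of a 1.4-fold lower number from compound 3 to compound 4 (0.14 log units; within the scatter) judged as hardly beyond the scatter. For compound 4 the estimate is 45 nM, with a range from 12 nM to 160 nM in this assay.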

Compound 4, half-maximal inhibitory concentration: 380 nM
Compound 4: the middle estimate sits 8.4-fold (0.93 log units) below what was measured, outside the stated range (above it).
By their numbers in this assay, from the lowest: compound 1; then compounds 2 and 3 (each within the scatter of the next); then compound 4.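

In this assay, isopropyl in place of propyl on a saturated chain carbon bound to an aromatic nitrogen and a saturated chain carbon gives a 6.1-fold higher number from compound 3 to compound 4 (0.79 log units; beyond the scatter). Within the data shown here, this pair shows that the position is sensitive to how the same carbons are joined, even though the heavy-atom count stays the same, which the earlier compounds, differing in several places, could not show. Nothing given here accounts for the step.

From the compounds shown here alone, it remains open how a longer chain or an amine at this place would read out, and whether the same change would give a similar step on the core of compound 1.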